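The compounds below may be only part of what the source reports. "The series", "measured", "known", "first", "only" and "open" are said of these compounds alone.

Measured compounds:
compound 1, `CC1=C(C(=O)OC(C)(C)C)C(c2ccoc2)NC(=S)N1`, giving 19% in an assay on membranes from HeLa cells for displacement of a labelled ligand from adenosine receptor A3 (Homo sapiens), read by scintillation counting, with a stated time of 180 min, tested at 1 uM; a higher number here means more inhibition at the concentration tested (going by the name of the read-out), a lower number less inhibition;
compound 2, `CC1=C(C(=O)OC(C)(C)C)C(c2cccs2)NC(=S)N1`, giving 22% in this assay;
compound 3, `CC1=C(C(=O)OCC(C)C)C(c2ccsc2)NC(=S)N1`, giving 2% in this assay.

On these numbers compound 3 stands lowest of the three; compound 1 lies nearest and compound 2 furthest, both beyond the scatter. Compound 4, `CC1=C(C(=O)OC(C)(C)C)C(c2ccsc2)NC(=S)N1`, is the compound not yet measured. It differs from compound 3 by tert-butyl in place of isobutyl on an oxygen next to a carbonyl group. Among the compounds with values here, no measured step changes this group: the only measured step, a number 3 percentage points higher from compound 1 to compound 2 (within the scatter), concerns the group on the saturated ring carbon and is within the scatter. Compound 1 and compound 2 both carry the tert-butyl and give similar numbers, while compound 3 carries the isobutyl and a different group on the saturated ring carbon; the two changes cannot be separated from the data at hand. Given that compound 1 gives 19% and compound 2 gives 22%, compound 4 is expected to lie nearer to them, with the step of a number 13 percentage points higher from compound 3 to compound 4 (beyond the scatter) expected in the upward direction. Compound 4 is therefore estimated at 15%, between 2% and 28%.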

Compound 4, a percentage reported as inhibition, at one concentration (the size of the read-out at that concentration, not a potency): 16%
Estimate against measurement, compound 4: 1 percentage points below, within the range that was stated.
By their numbers in this assay, from the lowest: compound 3; then compounds 4, 1 and 2 (each within the scatter of the next).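

Compound 4 separates the two changes that compound 3 carried together: with thiophen-3-yl held in place, tert-butyl in place of isobutyl on an oxygen next to a carbonyl group gives in this assay a number 14 percentage points higher from compound 3 to compound 4 (beyond the scatter) and so counts on its own at this position. The group on the saturated ring carbon does not separate the compounds carrying tert-butyl, with a number 6 percentage points lower from compound 2 to compound 4 (within the scatter) and a number 3 percentage points lower from compound 1 to compound 4 (within the scatter) leaving thiophen-3-yl, thiophen-2-yl and furan-3-yl apart by no more than the scatter. No measured evidence at hand accounts for the difference between the two butyl groups.

Going by these compounds, whether the step from isobutyl to tert-butyl holds with thiophen-2-yl or furan-3-yl on the saturated ring carbon remains open. So does the outcome of a shorter chain such as ethyl on that oxygen, or of a phenyl ring on the saturated ring carbon.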